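A few compounds are considered here, and "the series" means these few. Any claim that something is new, unique, unknown or untested is made for them only; others in the source may bear on it.

In a functional assay on MCF7 cells (Homo sapiens) for antiproliferative activity, read by MTT assay, with a stated time of 48 h (a lower number here means a stronger inhibitor, a higher number a weaker inhibitor), compound 1 `COc1ccc(-c2nc(Cl)cc(Nc3ccc(NC(=O)CN4CCCC4)cc3)n2)cc1` gives 23400 nM. Compound 2 `COc1ccc(-c2nc(Cl)c(-c3ccccc3)c(Nc3ccc(NC(=O)CN4CCCC4)cc3)n2)cc1` reads > 40000 nM, which is a limit of the assay and not a number. Compound 3 `COc1ccc(-c2nc(Cl)c(-c3ccccc3)c(Nc3ccc(NC(=O)CN(C)C)cc3)n2)cc1` differs from compound 2 by dimethylamino in place of pyrrolidin-1-yl on a saturated chain carbon bound to a carbonyl carbon, with dimethylamino in place of pyrrolidin-1-yl on a saturated chain carbon bound to a carbonyl carbon. Within the data shown here, the only measured step, an at least 1.7-fold higher number from compound 1 to compound 2 (0.23 log units; that floor lies within the scatter), lies at another place and gives only a floor, so it offers no measure of this exchange. No change beyond the scatter is therefore expected in this assay. The expected step is an at least 1.1-fold lower number from compound 2 to compound 3 (0.05 log units; that floor lies within the scatter). Compound 3 is estimated at 35000 nM, with an expected range of 15000 nM to 70000 nM.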

Compound 3, half-maximal inhibitory concentration: 17700 nM
For compound 3 the middle estimate is 2.0-fold (0.30 log units) above the measured one; the measured number falls inside the stated range.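

In this assay, dimethylamino in place of pyrrolidin-1-yl on a saturated chain carbon bound to a carbonyl carbon gives an at least 2.2-fold lower number from compound 2 to compound 3 (0.35 log units; beyond the scatter), so this position does respond to the amine attached there. The pyrrolidin-1-yl ring is thus not needed for a measurable value on the core of compound 2. The true size of the step stays unknown because compound 2 sits at a limit of the assay: the limit of > 40000 nM in this assay, at which 1 of the 3 values shown sits.

Piperidin-1-yl, morpholin-4-yl or a longer chain at this place remains open. So does whether the same exchange holds on the core of compound 1.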